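The source may hold more compounds than are shown below. What is called first, only, known or untested is meant among the compounds shown, and "the series" means these compounds.

Values in an ADME assay on microsomes from liver (Mus musculus) for metabolic stability, read by LC-MS, with a stated time of 10 min, tested at 0.5 uM; on this read-out higher numbers stand for a more stable compound and lower numbers for a less stable compound:
- compound 1 `c1ccc2c(c1)CN[C@H](CN(CCCN1CCNCC1)[C@H]1CCCc3cccnc31)C2`: 88%
- compound 2 `c1ccc2c(c1)CN[C@@H](CN(CCN1CCNCC1)[C@H]1CCCc3cccnc31)C2`: 79%
- compound 3 `NC(=O)N1CCN(CCCN(C[C@H]2Cc3ccccc3CN2)[C@H]2CCCc3cccnc32)CC1`: 42%

Not yet measured: compound 4 `c1cnc(CN(CCCN2CCNCC2)[C@H]2CCCc3cccnc32)nc1`.

Compound 1, at 88%, stands at the top of the three numbers together with compound 2, the two lying within the scatter of each other. Compound 3 lies beyond the scatter of compound 1.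

The change to compound 4 is pyrimidin-2-yl in place of 1,2,3,4-tetrahydroisoquinolin-3-yl on a saturated chain carbon bound to an amine nitrogen: pyrimidin-2-yl in place of 1,2,3,4-tetrahydroisoquinolin-3-yl, on a saturated chain carbon bound to an amine nitrogen. Compound 4 keeps the piperazin-1-yl group of compound 1.

Among the compounds with values here, only one measured step is available, a number 37 percentage points lower from compound 2 to compound 3 (beyond the scatter), and it is large. It concerns the piperazin-1-yl group, not the place changed here, so it bears only indirectly. It shows that a single change in this series can move this assay well beyond the scatter, but it does not give the size or direction of this step. Within the data shown here, no measured compound carries pyrimidin-2-yl, and none varies this place alone.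

With compound 1 so close to the top of the scale, a moderate fall is the expected direction, estimated as a number 13 percentage points lower from compound 1 to compound 4 (beyond the scatter), with little confidence. The estimate for compound 4 is 75%, with an expected range of 55% to 92%.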

Compound 4, percent of the compound remaining: 78%
Compound 4: the middle estimate sits 3 percentage points below what was measured; measured number inside the range.
By their numbers in this assay, from the lowest: compound 3; then compounds 4, 2 and 1 (each within the scatter of the next).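

In this assay, the place on a saturated chain carbon bound to an amine nitrogen now has its first direct read, a number 10 percentage points lower from compound 1 to compound 4 (within the scatter), with pyrimidin-2-yl in place of 1,2,3,4-tetrahydroisoquinolin-3-yl. The entering group has 6 heavy atoms, fewer than the group it replaces, no hydrogen-bond donor and no defined stereocentre, yet this read-out does not separate the two compounds, so the 1,2,3,4-tetrahydroisoquinolin-3-yl group is not required at this place for the stability seen here, at least when pyrimidin-2-yl replaces it. No measurement is available that would explain this result.

As far as these compounds go, a single replacement says little about the place as a whole, and it remains open whether phenyl, pyridin-2-yl or an open-chain primary amine on the same carbon would also stay within the scatter of compound 1. From the compounds shown here alone, it is also open whether the step seen with the other group, a number 37 percentage points lower from compound 2 to compound 3 (beyond the scatter), would recur on the pyrimidin-2-yl background if 4-carbamoylpiperazin-1-yl replaced the piperazin-1-yl group of compound 4.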